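The source may report more compounds than this note shows. Statements on the series, on what has been measured and on what is new or still open speak of the compounds shown alone.

Compound 1 `NS(=O)(=O)CCNc1nonc1/C(=N/O)Nc1ccc(F)c(Br)c1` stands lowest of the three numbers in an assay on isolated protein for inhibition of Indoleamine 2,3-dioxygenase 1 (Homo sapiens), read by fluorescence, with a stated time of 60 min (on this read-out higher numbers stand for weaker inhibition and lower numbers for stronger inhibition), at 71 nM. Compound 2 `CN(C)S(=O)(=O)CCNc1nonc1/C(=N/O)Nc1ccc(F)c(Br)c1` gives 105 nM in this assay, and compound 3 `O=S(=O)(CCNc1nonc1/C(=N/O)Nc1ccc(F)c(Br)c1)NCC1CC1` gives 312 nM. The steps measured so far, a 1.5-fold higher number from compound 1 to compound 2 (0.17 log units; within the scatter) and a 4.4-fold higher number from compound 1 to compound 3 (0.64 log units; beyond the scatter), together with a 3.0-fold higher number from compound 2 to compound 3 (0.47 log units; beyond the scatter), all alter the group on the sulfonamide nitrogen. Compound 4 `NS(=O)(=O)CCONc1nonc1/C(=N/O)Nc1ccc(F)c(Br)c1` differs from compound 1 at another place: 2-sulfamoylethoxy in place of 2-sulfamoylethyl on a nitrogen on an aromatic ring. Going by the values given here, no measured step touches the nitrogen on the aromatic ring, so the earlier steps are only an indirect guide. The losses seen in a 4.4-fold higher number from compound 1 to compound 3 (0.64 log units; beyond the scatter) and a 3.0-fold higher number from compound 2 to compound 3 (0.47 log units; beyond the scatter) suggest that a small loss, rather than a gain, is expected for compound 4. Compound 4 is therefore estimated at 200 nM, expected to lie between 60 nM and 700 nM, an expected 2.8-fold higher number from compound 1 to compound 4 (0.45 log units; beyond the scatter).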

Compound 4, half-maximal inhibitory concentration: 87 nM
Compound 4: middle estimate off by 2.3-fold (0.36 log units), on the high side, and the stated range covers the measured number.
By their numbers in this assay, from the lowest: compounds 1, 4 and 2 (each within the scatter of the next); then compound 3.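

Going by these compounds alone, the first change at the nitrogen on an aromatic ring, 2-sulfamoylethoxy in place of 2-sulfamoylethyl, gives a 1.2-fold higher number from compound 1 to compound 4 (0.09 log units; within the scatter) and so stays inside the scatter, unlike the cyclopropylmethyl change on the sulfonamide nitrogen. Set against the dimethylamino compound, the same chain gives a 1.2-fold lower number from compound 2 to compound 4 (0.08 log units; within the scatter) and also stays inside it. No supporting measurement accounts for this result. The compounds shown leave open whether a longer chain at this nitrogen, or a carboxylic acid in place of the terminal sulfonamide, would hold the number as well.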